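A few compounds are considered here, and "the series" means these few. Any claim that something is new, unique, unknown or untested is made for them only; others in the source may bear on it.

Working notes on the series. Compound 1 `C=CCn1c(=O)/c(=C\c2cccc(F)c2)[nH]c(=O)/c1=C\c1ccccc1OC` is read in a functional assay on U-937 cells (Homo sapiens) for cytotoxicity, read by CCK-8 assay, with a stated time of 72 h (a higher number here means a weaker inhibitor, a lower number a stronger inhibitor), and gives 2500 nM. Among the two compounds with a number in this assay, compound 1 holds the highest number. Within the data shown here, the nearest numbered entry is compound 2 `COc1ccccc1/C=c1/[nH]c(=O)/c(=C\c2nc[nH]c2C(C)(C)C)[nH]c1=O`, which in this assay gives 50 nM; the gap between compound 1 and compound 2 lies beyond the scatter, and the two structures differ in more than one place, so no single step links them. Compound 3 `C=CCn1c(=O)/c(=C\c2cc(OC)c(OC)c(OC)c2)[nH]c(=O)/c1=C\c1cccc(Br)c1` is reported in this assay as "not active" (no number reported), with no number attached.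

Among the measured compounds shown here, no pair of measured compounds differing in one place is available in this set, so nothing measured shows how a change of the present kind moves the read-out.

Compound 4 `C=CCn1c(=O)/c(=C\c2ccccc2F)[nH]c(=O)/c1=C\c1ccccc1OC` differs from compound 1 in one place: 2-fluorophenyl in place of 3-fluorophenyl on a double-bonded chain carbon bound to an aromatic carbon. The shared core and all other groups are unchanged. For the measured compounds named here, with no measured step of this kind to lean on, the expectation is a shift no larger than the scatter, in no preferred direction. Compound 4 is expected to give 2500 nM in this assay, with a range from 800 nM to 8000 nM. That estimate means a step of no change at the digits printed from compound 1 to compound 4 (within the scatter), expected to stay within the scatter.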

Compound 4, half-maximal inhibitory concentration: 5500 nM
Beside the measured number, compound 4's estimate is 2.2-fold (0.34 log units) below it; measured number inside the range.
By their numbers in this assay, from the lowest: compound 2; then compound 1; then compound 4.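

In this assay, 2-fluorophenyl in place of 3-fluorophenyl on a double-bonded chain carbon bound to an aromatic carbon goes with a 2.2-fold higher number from compound 1 to compound 4 (0.34 log units; beyond the scatter), the first single-place step available in this series. The two groups have the same atoms, joined differently, so the read-out at this place depends on more than the presence of fluorine on the phenyl ring, although the step is only modest. No measured information on the two groups accompanies this step, so the shift stands as an observation without an assigned cause.

Still open, going by these compounds, is how an unsubstituted phenyl, or a phenyl carrying an amine or a carboxylic acid, would read at this place relative to the two fluorophenyl groups. On these data alone, it is also open whether the same exchange of 3-fluorophenyl for 2-fluorophenyl would move the number in the same direction and by a similar amount if the rest of the structure differed, as this single step comes from one background only.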